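The source may hold more compounds than are shown below. What is called first, only, known or untested is meant among the compounds shown, and "the series" means these compounds.

Working notes on the series

Three members of the series have been run in a functional assay on HL-60 cells (Homo sapiens) for inhibition, read by CCK-8 assay, with a stated time of 48 h (a higher number here means a weaker inhibitor, a lower number a stronger inhibitor), so far. Compound 1 `Cc1ccc(-c2ccsc2S(=O)(=O)NCCNC(=S)Nc2cc(C(F)(F)F)cc(C(F)(F)F)c2)c(Oc2ccc(O)c(O)c2)c1` gives 3200 nM in this assay. Compound 2 `Cc1ccc(-c2ccsc2S(=O)(=O)NCCNC(=O)Nc2cccc([N+](=O)[O-])c2)c(Oc2ccc(O)c(O)c2)c1` gives 6000 nM in this assay. Compound 3 `CC(C)c1ccc(Oc2ccc(O)c(O)c2)c(-c2ccsc2S(=O)(=O)NCCNC(=S)Nc2cc(C(F)(F)F)cc(C(F)(F)F)c2)c1` gives 8200 nM in this assay, the highest of the three numbers. Against compound 2 the gap is within the scatter, so no order between compound 3 and compound 2 can be read. Against compound 1 the gap lies beyond the scatter, so compound 3 is the weaker inhibitor of that pair.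

Compound 4 `O=S(=O)(NCCNC(=S)Nc1cc(C(F)(F)F)cc(C(F)(F)F)c1)c1sccc1-c1ccccc1Oc1ccc(O)c(O)c1` has not yet been measured in this assay. It differs from compound 3 in one place: hydrogen in place of isopropyl on an aromatic carbon. Going by the values given here, no measured pair shows this exact change, so the size of the step is open. Among the compounds with values here, compound 1, which carries a methyl at the position where compound 3 carries the isopropyl, gives a lower number than compound 3, and that is the only guide available. On that basis the step from compound 3 to compound 4 is expected to be modest and downward, a 1.6-fold lower number from compound 3 to compound 4 (0.21 log units; within the scatter), with a real chance of no change beyond the scatter. Compound 4 is expected to give about 5000 nM in this assay, within a range of 2000 nM to 13000 nM.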

Compound 4, half-maximal inhibitory concentration: 4300 nM
Compound 4: middle estimate off by 1.2-fold (0.07 log units), on the high side; measured number inside the range.
By their numbers in this assay, from the lowest: compounds 1, 4, 2 and 3 (each within the scatter of the next, the first and the last beyond it).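

In this assay, the position para to the 3,4-dihydroxyphenoxy group now has direct pairs: hydrogen in place of isopropyl gives a 1.9-fold lower number from compound 3 to compound 4 (0.28 log units; within the scatter), and hydrogen in place of methyl gives a 1.3-fold higher number from compound 1 to compound 4 (0.13 log units; within the scatter). Neither change moves the number beyond the scatter, so in these pairs, the series keeps a number of the same order with no carbon group at this position, and the isopropyl and methyl groups cannot be told from hydrogen. Going by these compounds alone, compound 1 and compound 3 remain the only pair at this position whose gap lies beyond the scatter, with compound 4 falling within the scatter of both, and nothing at hand bears on why these numbers fall as they do.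

Still open, as far as these compounds go, is whether a different group at this position, such as an amine, a carboxylic acid or a longer chain, would move the number beyond the scatter. Also open, from the compounds shown here alone, is whether hydrogen in place of methyl would read the same with the nitrophenyl urea end of compound 2 as it does with the thiourea end of compound 1.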